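The compounds below may be only part of what the source reports. "The series", "measured", "known", "first", "only" and "open" are said of these compounds alone.

Measured compounds:
compound 1 `CC(=O)/C(=C/c1c(-c2ccccc2)[nH]c2ccccc12)C(=O)c1ccccc1` gives 79000 nM.
compound 2 `COc1ccc2[nH]c(-c3ccccc3)c(/C=C(\C#N)S(=O)(=O)c3ccccc3)c2c1` gives 9600 nM.
compound 3 `O=C(/C(=C\c1c(-c2ccccc2)[nH]c2ccccc12)C(=O)C(F)(F)F)c1ccco1` gives 16000 nM.

All three were read in a functional assay on HepG2 cells (Homo sapiens) for cytotoxicity, read by MTT assay, with a stated time of 96 h; on this read-out higher numbers stand for an effect only at larger amounts of compound and lower numbers for an effect already at smaller amounts. Compound 1 has the highest number of the three: compound 3 comes nearest and compound 2 lies furthest, and both gaps go beyond the usual scatter of this assay.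

Compound 4 `CCOC(=O)/C(=C/c1c(-c2ccccc2)[nH]c2ccccc12)C(=O)c1ccccc1` differs from compound 1 in one place: ethoxy in place of methyl on a carbonyl carbon. Among the measured compounds shown here, no measured pair in this set shares that change, so nothing shows directly how it acts. The step of a 1.2-fold lower number from compound 1 to compound 4 (0.08 log units; within the scatter) in this assay is expected to be small, in either direction, and not beyond the scatter. Compound 4 is therefore estimated at 65000 nM, between 25000 nM and 160000 nM.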

Compound 4, half-maximal effective concentration: 31000 nM
Compound 4: the middle estimate sits 2.1-fold (0.32 log units) above what was measured; measured number inside the range.
By their numbers in this assay, from the lowest: compounds 2, 3 and 4 (each within the scatter of the next, the first and the last beyond it); then compound 1.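

Among the compounds shown here, the step of a 2.5-fold lower number from compound 1 to compound 4 (0.41 log units; beyond the scatter) in this assay is the first comparison here that changes only one place, and it shows that this carbonyl carbon responds to the exchange of methyl for ethoxy, though only modestly. The change is from acetyl to ethoxycarbonyl, and the higher number stays with the acetyl compound. No information on hand accounts for the step. As far as these compounds go, whether a carboxylic acid, an amide or a longer chain such as butoxy at this place would move the number further remains open, as does whether the same step would appear with the other substituents on the shared core.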